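Working notes: ring substituent variation and antiproliferative growth inhibition

This account rests on a few compounds, and the source may have more. Where it says the series, first, only, none or still open, it means among the compounds named here.

Measured compounds:
compound 1, `Cc1ccc(S(=O)(=O)N2CCC(Cl)CC2)cc1`, gives > 100000 nM in a functional assay on SW1573 cells (Homo sapiens) for antiproliferative activity, read by sulforhodamine B assay, with a stated time of 48 h (a higher number here means a weaker inhibitor of growth, a lower number a stronger inhibitor of growth), a limit of the assay.
compound 2, `Cc1ccc(S(=O)(=O)N2CC[C@@H](Cl)C[C@@H]2CC(C)C)cc1`, gives 19000 nM in this assay.
compound 3, `CCCCCCC[C@H]1C[C@H](Cl)CCN1S(=O)(=O)c1ccc(C)cc1`, gives > 100000 nM in this assay, a limit of the assay.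

Compound 3 therefore stands only at the limit of > 100000 nM in this assay, at which 2 of the 3 values shown sit, with no number. The readable step is an at least 5.2-fold higher number from compound 2 to compound 3 (0.72 log units; beyond the scatter); the step of an at least 5.2-fold lower number from compound 1 to compound 2 (0.72 log units; beyond the scatter) runs the other way, while a step that the two limits leave unreadable from compound 1 to compound 3 cannot be read.

Compound 4, `Cc1ccc(S(=O)(=O)N2CC[C@@H](Cl)C[C@@H]2C2CCCCC2)cc1`, carries the change (cyclohexyl in place of heptyl on a saturated ring carbon). The bearing steps are those from compound 2 to compound 3 and from compound 1 to compound 2; they place compound 4 between a number like that of compound 2 and the limit seen for compound 3. The expected value for compound 4 is 50000 nM, range 15000 nM to 150000 nM, an expected step of an at least 2.0-fold lower number from compound 3 to compound 4 (0.30 log units; that floor lies within the scatter).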

Compound 4, concentration for 50% growth inhibition: 53000 nM
Compound 4: the middle estimate sits 1.1-fold (0.03 log units) below what was measured; low and high end bracket the measured number.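

Compound 4 places a cyclohexyl on the saturated ring carbon next to the ring nitrogen and in this assay gives a readable number, while a 2.8-fold higher number from compound 2 to compound 4 (0.45 log units; beyond the scatter) separates cyclohexyl from isobutyl. Against hydrogen and heptyl only floors can be given: an at least 1.8-fold lower number from compound 1 to compound 4 (0.27 log units; that floor lies within the scatter) and an at least 1.8-fold lower number from compound 3 to compound 4 (0.27 log units; that floor lies within the scatter). Compound 1 and compound 3 each stand at a limit, so neither step has a full size: the limit of > 100000 nM in this assay, at which 2 of the 4 values shown sit.

From the compounds shown here alone, whether an ethyl, a phenyl or an aminomethyl group at this position would bring the number below that of compound 2 stays open.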